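The source may report more compounds than this note shows. Statements on the series, on what has been measured and on what is new or still open speak of the compounds shown alone.

Working notes on the crown-ether ester series.

Among the measured compounds shown here, in a functional assay on HeLa cells (Homo sapiens) for inhibition, read by sulforhodamine B assay, with a stated time of 48 h (on this read-out lower numbers stand for stronger inhibition of growth and higher numbers for weaker inhibition of growth), compound 1 `O=C(CCCCC1CCCCC1)OCC1COCCOCCOCCOCCOCCO1` gives 71000 nM, the only full number in the set. Compound 2 `CC/C=C/CC(=O)OCC1COCCOCCOCCOCCOCCO1` reaches only the limit of this assay, > 100000 nM. Compound 3 `O=C(OCC1COCCOCCOCCOCCOCCO1)c1cccnc1` likewise stands at the limit, > 100000 nM. So compound 3 is read only as a floor, and the limit of > 100000 nM in this assay, at which 2 of the 3 values shown sit, describes where two of the three values sit. The steps from compound 1 read an at least 1.4-fold higher number from compound 1 to compound 2 (0.14 log units; that floor lies within the scatter) and an at least 1.4-fold higher number from compound 1 to compound 3 (0.14 log units; that floor lies within the scatter); between the two limits the step is a step that the two limits leave unreadable from compound 2 to compound 3.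

Compound 4 `CC(=O)OCC1COCCOCCOCCOCCOCCO1` is the next variation on the carbonyl carbon: methyl in place of pyridin-3-yl on a carbonyl carbon. For the measured compounds named here, the steps that bear on this position, from compound 1 to compound 3 and from compound 2 to compound 3, are small or unreadable, and no exchange at the carbonyl carbon has so far moved a value beyond the scatter. The expected step in this assay is therefore a step that the limit leaves unreadable from compound 3 to compound 4, with a fair chance that compound 4 again returns only the limit. Compound 4 is estimated at 120000 nM, within 50000 nM to 300000 nM.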

Compound 4, concentration for 50% growth inhibition: > 100000 nM
Compound 4 gave a limit, no number; the forecaster's own chance of this, stated with the estimate: 70%; the middle value lies beyond the limit too.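

The series now carries methyl, pent-2-en-1-yl and pyridin-3-yl on the carbonyl carbon, and all three esters return only a limit, not a number, in this assay: the limit of > 100000 nM in this assay, at which 3 of the 4 values shown sit.

The one readable new step is an at least 1.4-fold higher number from compound 1 to compound 4 (0.14 log units; that floor lies within the scatter), so even with methyl at this position, compound 4 is not shown to differ from compound 1, which carries 4-cyclohexylbutyl. The steps to compound 4 from compound 2 and from compound 3 cannot be read, since both ends of each are limits.

As far as these compounds go, it remains open whether any group on this carbonyl carbon moves growth inhibition beyond the scatter on the shared core. A longer chain such as dodecyl, or an amine or carboxylic acid at the end of the acyl chain, would bear on that question.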